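Swapping cyclohexyl for phenyl in a growth-inhibition series

This account rests on a few compounds, and the source may have more. Where it says the series, first, only, none or still open, it means among the compounds named here.

For the measured compounds named here, in a functional assay on MV4-11 cells (Homo sapiens) for antiproliferative activity, read by CellTiter-Glo, with a stated time of 72 h (a higher number here means a weaker inhibitor of growth, a lower number a stronger inhibitor of growth), compound 1 (`COCCN[C@H]1CC[C@H](Nc2cc(-c3csc(NCC4CCCC4)n3)c(Cl)cn2)CC1`) gives 2160 nM and compound 2 (`COCCN[C@H]1CC[C@H](Nc2cc(-c3csc(NCC4CCCCC4)n3)c(Cl)cn2)CC1`) gives 820 nM as the lower of the two numbers measured so far. Compound 3 (`COCCN[C@H]1CC[C@H](Nc2cc(-c3csc(NCc4ccccc4)n3)c(Cl)cn2)CC1`) is still unmeasured and carries phenyl in place of cyclohexyl on a saturated chain carbon bound to a nitrogen on an aromatic ring. Going by the values given here, the only measured step at this place (a 2.6-fold lower number from compound 1 to compound 2 (0.42 log units; beyond the scatter)) puts cyclohexyl in place of cyclopentyl. It is modest and involves no phenyl, so it offers limited guidance. Only a small step towards a higher number in this assay is therefore expected, perhaps none beyond the scatter. The estimated change is small (a 1.5-fold higher number from compound 2 to compound 3 (0.17 log units; within the scatter)) and carries wide uncertainty. Compound 3 is estimated at 1200 nM with an expected range from 450 nM to 3000 nM as the likely span of a measurement.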

Compound 3, concentration for 50% growth inhibition: 330 nM
Compound 3: middle estimate off by 3.6-fold (0.56 log units), on the high side, outside the stated range (below it).
By their numbers in this assay, from the lowest: compound 3; then compound 2; then compound 1.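

In this assay, phenyl in place of cyclohexyl on a saturated chain carbon bound to a nitrogen on an aromatic ring gives a 2.5-fold lower number from compound 2 to compound 3 (0.40 log units; beyond the scatter). This shows that the ring here need not be saturated, and that an aromatic ring with the same count of heavy atoms gives the lowest number of the three. Phenyl in place of cyclopentyl gives a 6.5-fold lower number from compound 1 to compound 3 (0.82 log units; beyond the scatter), a wider span at this position than the one earlier step showed, although no measurement available here accounts for the gain.

The compounds shown leave open whether a pyridine ring in place of phenyl, or a fluorine or methoxy group on the phenyl ring, would lower the number further. They also leave open how phenethyl in place of benzyl would compare.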